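This account rests on a few compounds, and the source may have more. Where it says the series, first, only, none or still open, it means among the compounds named here.

For the measured compounds named here, in a functional assay on V79 cells (Cricetulus griseus) for cytotoxicity, read by colony formation (a higher number here means a weaker inhibitor, a lower number a stronger inhibitor), compound 2 `CC1CN(c2c(F)cc3c(=O)c(C(=O)O)cn(C4CC4)c3c2Cl)CC(C)N1` gives 140 ug/mL, the higher of the two numbers so far. Compound 1 `CC1(CN)CCN(c2c(F)cc3c(=O)c(C(=O)O)cn(C4CC4)c3c2Cl)C1` shares the core and differs only in one group, and the step between them is large and beyond the scatter: an 18-fold higher number from compound 1 to compound 2 (1.24 log units; beyond the scatter). Compound 3 `NC1CCCN(c2c(F)cc3c(=O)c(C(=O)O)cn(C4CC4)c3c2Cl)C1` changes that group again, on the same aromatic carbon, ortho to a chloro group and ortho to a fluoro group: 3-aminopiperidin-1-yl in place of 3,5-dimethylpiperazin-1-yl on an aromatic carbon. The step above is the only measured one that bears on this change. The entering group resembles the 3-(aminomethyl)-3-methylpyrrolidin-1-yl of compound 1, at 8 ug/mL, in carrying its amine outside the ring, so a sizeable move toward a lower number is expected, though perhaps not the whole distance. Going by the values given here, no measured compound carries the 3-aminopiperidin-1-yl group itself. The expected change in this assay is a 7.0-fold lower number from compound 2 to compound 3 (0.85 log units; beyond the scatter). For compound 3 the estimated value is 20 ug/mL, within an expected range of 6 ug/mL to 80 ug/mL.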

Compound 3, half-maximal inhibitory concentration: 24 ug/mL
Estimate against measurement, compound 3: 1.2-fold (0.08 log units) below; low and high end bracket the measured number.
By their numbers in this assay, from the lowest: compound 1; then compound 3; then compound 2.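

In this assay the change from 3,5-dimethylpiperazin-1-yl to 3-aminopiperidin-1-yl on this aromatic carbon gives a 5.8-fold lower number from compound 2 to compound 3 (0.77 log units; beyond the scatter) and shows that the low number of compound 1 is not unique to the 3-(aminomethyl)-3-methylpyrrolidin-1-yl group. Among these three compounds, the two groups carrying their amine outside the ring both stand below compound 2, yet they are not interchangeable: the comparison of the two gives a 3.0-fold higher number from compound 1 to compound 3 (0.48 log units; beyond the scatter) and leaves compound 1 with the lowest number. Nothing available explains these differences.

Going by these compounds, what a hydroxyl group in place of the amine of 3-aminopiperidin-1-yl would give remains open, as does the effect of a longer aminoethyl chain on the same ring. On these data alone, it is also open whether this order of the three groups would hold with a hydrogen in place of the chloro group.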